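Extending a nitrile side chain on a shared phenolic core

A few compounds are considered here, and "the series" means these few. Any claim that something is new, unique, unknown or untested is made for them only; others in the source may bear on it.

Among the measured compounds shown here, compound 2 `CCc1cc(C(C)=O)c(O)cc1OCCCCCCC(C)(C)C#N` stands lowest of the two compounds measured so far in an assay on isolated protein for inhibition of leukotriene B4 receptor 1 (Homo sapiens), tested at 10 uM (on this read-out lower numbers stand for less inhibition and higher numbers for more inhibition at the one concentration tested (going by the name of the read-out)), where compound 2 gives 65%. For the measured compounds named here, its only neighbour is compound 1 `CCc1cc(C(C)=O)c(O)cc1OCCCCC#N`, which in this assay gives 92%; between them the change is a number 27 percentage points lower from compound 1 to compound 2 (beyond the scatter), a difference beyond the usual scatter. Compound 3 `CCc1cc(C(C)=O)c(O)cc1OCCCCCCCC(C)(C)C#N` has not yet been measured. It differs from compound 2 by 2-cyano-2-methylpropyl in place of 1-cyano-1-methylethyl on a saturated chain carbon, six bonds along the chain from an oxygen on an aromatic ring. Going by the values given here, only one measured step bears on this change: from compound 1 to compound 2 the chain grew longer and inhibition fell by a modest amount, so a further lengthening of the chain in compound 3 is expected to lower the number again, though by less, since the added piece is smaller than before. The estimated step is a number 10 percentage points lower from compound 2 to compound 3 (within the scatter), with a range wide enough to include no change beyond the scatter. Compound 3 is thus expected to give 55%, between 35% and 75%.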

Compound 3, a percentage reported as inhibition, at one concentration (the size of the read-out at that concentration, not a potency): 66%
The estimate for compound 3 lay 11 percentage points below the measured number; the measured number falls inside the stated range.
By their numbers in this assay, from the lowest: compounds 2 and 3 (each within the scatter of the next); then compound 1.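

In this assay, the further extension of the chain at this position gives a number 1 percentage points higher from compound 2 to compound 3 (within the scatter), so this step does not repeat the earlier fall and the two side chains cannot be told apart here. Measured against the short chain, 4-cyano-4-methylpentyl in place of cyano gives a number 26 percentage points lower from compound 1 to compound 3 (beyond the scatter), which shows that the loss seen with compound 2 is still present in compound 3. Nothing shown here explains why the longer chains behave alike.

Because both longer chains carry the added length and the methyl groups beside the nitrile together, the compounds shown cannot separate the part played by each. From the compounds shown here alone, an unbranched nitrile chain of matching length would bear on that question, while a carboxylic acid in place of the nitrile, or a still longer chain, remains open.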